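This account rests on a few compounds, and the source may have more. Where it says the series, first, only, none or still open, it means among the compounds named here.

Of the compounds shown here, three have so far been tested in an assay on isolated protein for inhibition of homeodomain-interacting protein kinase 1 (Homo sapiens), read by AlphaScreen, with a stated time of 1 h (a higher number here means a weaker inhibitor, a lower number a stronger inhibitor), and none of them has yielded a number. Compound 1 `C=CCNC(=O)Nc1cncc2nc(-c3ccccc3)cnc12` sits at the limit of this assay, with > 100000 nM as a limit only. Compound 2 `c1ccc(Nc2cncc3nc(-c4ccc(N5CCCCC5)cc4)cnc23)cc1` likewise records only a limit in this assay, > 100000 nM. Compound 3 `CCNC(=O)Nc1nccc2nc(-c3ccccc3)cnc12`, the starting point of the step that follows, also gives just a limit in this assay, > 100000 nM. So compound 3 stands nowhere in particular among the measured compounds: all three values sit at the same limit, as summarised by the limit of > 100000 nM in this assay, at which 3 of the 3 values shown sit, and no ordering among them can be drawn.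

Compound 4 `COc1cccc(Nc2nccc3nc(-c4ccccc4)cnc23)c1` differs from compound 3 in one place: 3-methoxyphenyl in place of ethylcarbamoyl on a nitrogen on an aromatic ring. Within the data shown here, no step between measured compounds is available to guide the expectation. Compound 2 carries an aryl group on the corresponding nitrogen and gives only a limit, so there is no indication from the measured compounds that an aryl substituent on that nitrogen brings the value down from the limit. Compound 4 is therefore expected to come out near 60000 nM, within a range from 10000 nM to 300000 nM. The implied step, an at least 1.6-fold lower number from compound 3 to compound 4 (0.22 log units; that floor lies within the scatter), is expected to be no step beyond the scatter, with a real chance that this assay again reports only a limit.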

Compound 4, half-maximal inhibitory concentration: > 100000 nM
Compound 4 was reported as a limit; the forecaster's own chance of this, stated with the estimate: 60%; at least 1.6-fold (0.22 log units) between middle value and limit.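

In this assay compound 4 gives > 100000 nM, which is a limit and not a number. Compound 3 also gives only a limit, so no step can be read between compound 3 and compound 4, and the picture stays flat: the limit of > 100000 nM in this assay, at which 4 of the 4 values shown sit.

The compounds shown leave open which structure, if any, would give a measurable value in this assay.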